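Aryl swap on the five-membered ring of the series

The source may hold more compounds than are shown below. What is called first, only, known or untested is meant among the compounds shown, and "the series" means these compounds.

Compound 2 `CCOC(=O)C1=Cc2ccccc2OC1(OCc1cc(-c2ccc3ccccc3c2)no1)C(F)(F)F` reaches only a limit in a functional assay on HeLa cells (Homo sapiens) for inhibition, read by MTT assay, with a stated time of 24 h (on this read-out lower numbers stand for stronger inhibition and higher numbers for weaker inhibition), where compound 2 gives > 150000 nM. Its acid analogue compound 3 `O=C(O)C1=Cc2ccccc2OC1(OCc1cc(-c2ccc3ccccc3c2)no1)C(F)(F)F` likewise sits at a limit and gives > 150000 nM. The step that the two limits leave unreadable from compound 2 to compound 3 therefore tells nothing of size; both values fall on (the limit of > 150000 nM in this assay, at which 2 of the 3 values shown sit). Compound 1 `CCOC(=O)C1=Cc2ccccc2OC1(OCc1cn(-c2ccc(F)cc2)nn1)C(F)(F)F`, carrying the 4-fluorophenyl on a different five-membered aromatic ring, gives 8400 nM. Compound 4 `CCOC(=O)C1=Cc2ccccc2OC1(OCc1cc(-c2ccc(F)cc2)no1)C(F)(F)F` differs from compound 2 by 4-fluorophenyl in place of naphthalen-2-yl on an aromatic carbon. Among the compounds with values here, no measured step covers this change, so the direction of an at least 5.0-fold lower number from compound 2 to compound 4 (0.69 log units; beyond the scatter) expected here rests only on the limit for compound 2 and on the value of compound 1. Compound 4 is expected to give about 30000 nM, within a range from 5000 nM to 150000 nM, with a real chance that only a limit is again reported.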

Compound 4, half-maximal inhibitory concentration: 42300 nM
Compound 4: the middle estimate sits 1.4-fold (0.15 log units) below what was measured; the measured number falls inside the stated range.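

In this assay, the swap of naphthalen-2-yl for 4-fluorophenyl on this aromatic carbon gives the first readable direction in the series: an at least 3.5-fold lower number from compound 2 to compound 4 (0.54 log units; beyond the scatter). This position therefore responds to the aryl group, and the ring with 1 nitrogen and 1 oxygen can give a number rather than a limit. The size remains a minimum only, because compound 2 stands at a limit: the limit of > 150000 nM in this assay, at which 2 of the 4 values shown sit.

Going by these compounds, the step from ethyl ester to carboxylic acid cannot be read, and how that change behaves alongside 4-fluorophenyl stays open. Also open, on these data alone, is how an amine on the aryl ring would read here.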